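A few compounds are considered here, and "the series" means these few. Any claim that something is new, unique, unknown or untested is made for them only; others in the source may bear on it.

Two compounds of this series have numbers in a functional assay on SNB-75 cells (Homo sapiens) for inhibition, read by sulforhodamine B assay, with a stated time of 48 h, tested at 10 uM; a higher number here means more inhibition of growth at the concentration tested, a lower number less inhibition of growth. Compound 1 `c1ccc(-c2nc3sc(-c4ccccc4)cn3n2)cc1` gives 15%. Compound 2 `COc1ccc(-c2nc3sc(-c4ccc(Cl)cc4)cn3n2)cc1` gives -1.66%, the lowest of the two, with compound 1 the nearest and standing higher by a gap beyond the scatter. Compound 3 `Clc1ccc(-c2cn3nc(-c4ccccc4)nc3s2)cc1` is not yet measured; it differs from compound 2 in one place: hydrogen in place of methoxy on an aromatic carbon. Going by the values given here, no pair of measured compounds differing in one place exists to guide this step, so the expected step from compound 2 to compound 3 in this assay is modest and upward, probably within the scatter, at a number 8.7 percentage points higher from compound 2 to compound 3 (within the scatter). Compound 3 is estimated at 7%, in a range from -8% to 24%.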

Compound 3, percent growth inhibition at one concentration: 36%
Estimate against measurement, compound 3: 29 percentage points below; measured number outside the range, above it.
By their numbers in this assay, from the lowest: compound 2; then compound 1; then compound 3.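

Hydrogen in place of methoxy on the aromatic carbon para to a large group gives a number 37.7 percentage points higher from compound 2 to compound 3 (beyond the scatter) and shows that this position responds strongly to the change. Chloro in place of hydrogen on an aromatic carbon gives a number 21 percentage points higher from compound 1 to compound 3 (beyond the scatter) and leaves compound 3 the highest of the three, with both steps beyond the scatter. Nothing measured on these compounds bears on the reason for either step.

As far as these compounds go, whether a fluoro, a methyl or an amine at the methoxy position would match hydrogen remains open. Also open, from the compounds shown here alone, is whether the chloro step holds with the methoxy present.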